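Bromo for trifluoromethyl on the anilide ring

The compounds below may be only part of what the source reports. "The series", "measured", "known", "first", "only" and "open" are said of these compounds alone.

Two salicylanilides bearing two trifluoromethyl groups have been measured so far. In an assay for inhibition of transmembrane protease serine 4 (Homo sapiens), read by fluorescence (on this read-out lower numbers stand for stronger inhibition and higher numbers for weaker inhibition), compound 1 `O=C(Nc1cc(C(F)(F)F)ccc1C(F)(F)F)c1cc(Cl)ccc1O` gives 20000 nM, and in this assay compound 2 `O=C(Nc1ccc(C(F)(F)F)c(C(F)(F)F)c1)c1cc(Cl)ccc1O` gives 13000 nM; the two values lie within the scatter of each other, so neither is distinguished from the other. Compound 3 `O=C(Nc1ccc(Br)c(C(F)(F)F)c1)c1cc(Cl)ccc1O` follows from compound 2 by bromo in place of trifluoromethyl on an aromatic carbon. For the measured compounds named here, no measured pair shows this exchange, so nothing beyond the scatter is expected, in either direction; the step from compound 2 to compound 3 is estimated as no change at the digits printed from compound 2 to compound 3 (within the scatter). For compound 3 the expected value is 13000 nM, with a range from 5000 nM to 35000 nM.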

Compound 3, half-maximal inhibitory concentration: 30000 nM
For compound 3 the middle estimate is 2.3-fold (0.36 log units) below the measured one; the range from low to high includes it.
By their numbers in this assay, from the lowest: compounds 2, 1 and 3 (each within the scatter of the next, the first and the last beyond it).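

In this assay, putting bromo in place of trifluoromethyl at this position, ortho to a trifluoromethyl group and para to a large group, gives a 2.3-fold higher number from compound 2 to compound 3 (0.36 log units; beyond the scatter). For the compounds shown here, this single-place step is the first and shows that the position responds to this exchange, modestly and toward weaker inhibition. No measurement at hand bears on the reason for this step.

Open, going by these compounds, is whether a nitrile or an amine at this position would give lower numbers than trifluoromethyl. Also open, on these data alone, is whether the same exchange at the other trifluoromethyl group of compound 2 would give a similar step.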